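This account rests on a few compounds, and the source may have more. Where it says the series, first, only, none or still open, it means among the compounds named here.

Compound 3 `O=C(Nc1ccccc1F)Nc1cc2ncncc2cc1OCc1cccc(Cl)c1` gives the highest number of the three measured in a functional assay on GBM3 cells (Homo sapiens) for antiproliferative activity, read by WST assay, with a stated time of 72 h (on this read-out lower numbers stand for stronger inhibition and higher numbers for weaker inhibition), at 7500 nM, with compound 2 `O=C(Nc1cccc(Cl)c1)Nc1cc2ncncc2cc1OCc1ccccc1` at 6400 nM and compound 1 `O=C(Nc1ccccc1F)Nc1cc2ncncc2cc1OCc1ccccc1F` at 3800 nM both within the scatter of it. Compound 4 `O=C(Nc1ccccc1F)Nc1cc2ncncc2cc1OCc1ccccc1` differs from compound 3 by hydrogen in place of chloro on an aromatic carbon. For the measured compounds named here, the only measured step touching this part of the molecule is a 2.0-fold higher number from compound 1 to compound 3 (0.30 log units; within the scatter), a change at the same benzyl position that stayed within the scatter. Going by the values given here, no measured pair shows chloro against hydrogen directly. Therefore no step beyond the scatter is expected in this assay, with a mild drift toward the smaller numbers of compound 1 and compound 2 possible. Compound 4 is estimated at 5000 nM, between 2500 nM and 10000 nM, which corresponds to an expected step of a 1.5-fold lower number from compound 3 to compound 4 (0.18 log units; within the scatter).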

Compound 4, half-maximal inhibitory concentration: 5900 nM
Compound 4: the middle estimate sits 1.2-fold (0.07 log units) below what was measured, within the range that was stated.
By their numbers in this assay, from the lowest: compounds 1, 4, 2 and 3 (each within the scatter of the next).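

In this assay, for the compounds shown here, hydrogen in place of chloro on the benzyl group gives a 1.3-fold lower number from compound 3 to compound 4 (0.10 log units; within the scatter), the first direct reading of this change, and hydrogen in place of fluoro on that group gives a 1.6-fold higher number from compound 1 to compound 4 (0.19 log units; within the scatter). On the amide-type nitrogen, 2-fluorophenyl in place of 3-chlorophenyl gives a 1.1-fold lower number from compound 2 to compound 4 (0.04 log units; within the scatter). At both places, then, these halogen changes stay within the scatter, and the unsubstituted benzyl group reads no differently from its halogenated forms.

On these data alone, whether an amine, a carboxylic acid or a longer chain at the benzyl position would move the number beyond the scatter remains open. Nothing available accounts for these small steps.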